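Compound 3 to compound 4: expected step

The source may report more compounds than this note shows. Statements on the series, on what has been measured and on what is new or still open speak of the compounds shown alone.

Measured in a functional assay on HeLa cells (Homo sapiens) for inhibition, read by MTT assay, with a stated time of 72 h (on this read-out higher numbers stand for weaker inhibition and lower numbers for stronger inhibition), as follows
- Compound 1 `COc1cc(O)c(CC=C(C)C)c(O)c1C(=O)/C=C/c1ccc(O)c(O)c1` gives 38100 nM
- Compound 2 `COc1cc(O)c(CC=C(C)C)c(O)c1C(=O)/C=C/c1cccc([N+](=O)[O-])c1` gives 16500 nM
- Compound 3 `COc1cc(OC)c(C(=O)/C=C/c2ccccc2OC)c(OC)c1` gives 19600 nM

The number for compound 3 lies within the scatter of those of both compound 1 and compound 2, although those two stand apart. Compound 4 `COc1cc(OC)c(C(=O)/C=C/c2ccc(O)c(O)c2)c(OC)c1` carries 3,4-dihydroxyphenyl in place of 2-methoxyphenyl (3,4-dihydroxyphenyl in place of 2-methoxyphenyl on a double-bonded chain carbon bound to a double-bonded chain carbon) on a double-bonded chain carbon bound to a double-bonded chain carbon. For the measured compounds named here, the only measured step involving the entering group is a 2.3-fold lower number from compound 1 to compound 2 (0.36 log units; beyond the scatter) where 3,4-dihydroxyphenyl leaves, though on a different core and with 3-nitrophenyl as its partner. Read in reverse, that modest step suggests a similarly modest rise in this assay with much uncertainty. The expected change is a 1.6-fold higher number from compound 3 to compound 4 (0.21 log units; within the scatter) as estimated here. Compound 4 is expected at 32000 nM with an estimated range from 13000 nM to 75000 nM in this read-out.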

Compound 4, half-maximal inhibitory concentration: 15800 nM
Compound 4: the middle estimate sits 2.0-fold (0.31 log units) above what was measured, within the range that was stated.
By their numbers in this assay, from the lowest: compounds 4, 2, 3 and 1 (each within the scatter of the next, the first and the last beyond it).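

In this assay, 3,4-dihydroxyphenyl in place of 2-methoxyphenyl on the shared core gives a 1.2-fold lower number from compound 3 to compound 4 (0.09 log units; within the scatter), so this exchange of a ring without hydrogen-bond donors for one carrying them leaves the number unresolved from that of compound 3. The earlier step at this place, a 2.3-fold lower number from compound 1 to compound 2 (0.36 log units; beyond the scatter), involved a different core and a different partner group, so the two steps do not establish a common trend. No available evidence bears on this result. Still open, going by these compounds, is whether an aminophenyl or carboxyphenyl group at this place would give a step beyond the scatter, and whether 2-methoxyphenyl would behave alike on the core of compound 1.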